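Swapping a Pentyl Chain for a Dimethylaminoethyl Chain

The compounds below may be only part of what the source reports. "The series", "measured", "known", "first", "only" and "open" are said of these compounds alone.

Three compounds share one core and differ only in the chain on the amine that sits on an aromatic ring. Compound 1 `CCCNc1nn2c(=O)cc(C(F)(F)F)nc2s1` carries the shortest chain; in an assay on cells for inhibition of alkaline phosphatase, tissue-nonspecific isozyme (Homo sapiens), read by luminescence, with stated times of 7 min and 20 min (a higher number here means a weaker inhibitor, a lower number a stronger inhibitor), compound 1 gives 1440 nM. Compound 2 `CCCCNc1nn2c(=O)cc(C(F)(F)F)nc2s1` gives 880 nM in this assay, and compound 3 `CCCCCNc1nn2c(=O)cc(C(F)(F)F)nc2s1` gives 610 nM, the lowest of the three numbers. Each added chain carbon moved the number a little: a 1.6-fold lower number from compound 1 to compound 2 (0.21 log units; within the scatter), a 1.4-fold lower number from compound 2 to compound 3 (0.16 log units; within the scatter), and over both additions a 2.4-fold lower number from compound 1 to compound 3 (0.37 log units; beyond the scatter).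

Compound 4 `CN(C)CCNc1nn2c(=O)cc(C(F)(F)F)nc2s1` keeps the same chain length as compound 3 but replaces a chain end: dimethylamino in place of propyl on a saturated chain carbon, two bonds along the chain from a nitrogen on an aromatic ring. The measured steps only show what a longer chain does; none of them exchanges a chain carbon for a nitrogen, so they bear on this change only loosely. For the measured compounds named here, with no direct precedent, the expected step in this assay is a 1.6-fold higher number from compound 3 to compound 4 (0.21 log units; within the scatter), not beyond the scatter in either direction. Compound 4 is therefore estimated at 1000 nM, within a range from 350 nM to 3000 nM.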

Compound 4, half-maximal inhibitory concentration: 450 nM
Compound 4: middle estimate off by 2.2-fold (0.35 log units), on the high side, within the range that was stated.
By their numbers in this assay, from the lowest: compounds 4, 3, 2 and 1 (each within the scatter of the next, the first and the last beyond it).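

Replacing the propyl end of the chain with dimethylamino brings a nitrogen and a hydrogen-bond acceptor into the chain, and in this assay the result is a 1.4-fold lower number from compound 3 to compound 4 (0.13 log units; within the scatter). Against the butyl chain of compound 2 the result is a 2.0-fold lower number from compound 2 to compound 4 (0.29 log units; within the scatter), so compound 4 cannot be told apart from either compound, and the chain need not be all carbon at this position. Only the comparison with the propyl chain of compound 1 gives a clear difference, a 3.2-fold lower number from compound 1 to compound 4 (0.51 log units; beyond the scatter), and nothing measured here bears on why the nitrogen is accepted.

The compounds shown leave open how a chain ending in a carboxylic acid or in a ring amine such as morpholine would read in this assay. They also leave open whether a longer chain ending in dimethylamino would read the same.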